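The source may hold more compounds than are shown below. What is called first, only, known or untested is meant among the compounds shown, and "the series" means these compounds.

Compound 1 `O=C1NCCC12CCN(c1c(Cl)cncc1-c1ccsc1)CC2` is the strongest grower inhibitor among the three measured compounds: in a functional assay on MV4-11 cells (Homo sapiens) for inhibition, read by resazurin assay, with a stated time of 72 h (a higher number here means a weaker inhibitor of growth, a lower number a stronger inhibitor of growth), compound 1 gives 190 nM. Compound 2 `Cc1csc(-c2cncc(Cl)c2N2CCC3(CCNC3=O)CC2)c1` gives 650 nM, and compound 3 `CC(C)(C)OC(=O)N1CCN(Cc2ccc(-c3cncc(Cl)c3N3CCC4(CCNC4=O)CC3)s2)CC1` gives 5150 nM, so compound 1 stands at the low end, with compound 2 nearest and compound 3 furthest away.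

Compound 4 `Cn1cccc1-c1cncc(Cl)c1N1CCC2(CCNC2=O)CC1` is not yet measured. It differs from compound 1 in a single place: 1-methyl-1H-pyrrol-2-yl in place of thiophen-3-yl on an aromatic carbon. Within the data shown here, the one measured step that speaks to such a swap of the five-membered aromatic ring is the move from thiophen-3-yl to 4-methylthiophen-2-yl, which gave a 3.4-fold higher number from compound 1 to compound 2 (0.53 log units; beyond the scatter). Compound 3 carries a much larger group on its thiophene and is not a close guide here. A ring of similar size bearing a methyl, as in compound 4, is therefore expected to cost some potency in this assay, probably a modest step rather than a large one.

For compound 4 the expected step is a 2.6-fold higher number from compound 1 to compound 4 (0.42 log units; beyond the scatter), giving an estimate of 500 nM, within a range from 180 nM to 1500 nM.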

Compound 4, concentration for 50% growth inhibition: 900 nM
The estimate for compound 4 lay 1.8-fold (0.26 log units) below the measured number; the range from low to high includes it.
By their numbers in this assay, from the lowest: compound 1; then compounds 2 and 4 (each within the scatter of the next); then compound 3.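

In this assay, putting 1-methyl-1H-pyrrol-2-yl in place of thiophen-3-yl, on the aromatic carbon ortho to a large group, gives a 4.7-fold higher number from compound 1 to compound 4 (0.68 log units; beyond the scatter), so a ring holding nitrogen instead of sulfur also falls on the weaker side of compound 1. The two methyl-bearing rings cannot be told apart, with 1-methyl-1H-pyrrol-2-yl in place of 4-methylthiophen-2-yl giving a 1.4-fold higher number from compound 2 to compound 4 (0.14 log units; within the scatter). At this position, then, changing from the sulfur ring to the nitrogen ring shows no clear effect when both rings carry a methyl, and no measurement offered here explains the loss from compound 1. Still open, going by these compounds, is whether the methyl or the change of ring accounts for that loss, and whether a plain pyrrol-2-yl or a phenyl ring would stay close to compound 1.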